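Notes on compound 1 and the unmeasured compound 4

This account rests on a few compounds, and the source may have more. Where it says the series, first, only, none or still open, it means among the compounds named here.

Among the measured compounds shown here, compound 1 `O=c1ccc2cc(OCc3cc(-c4ccccc4Cl)no3)ccc2o1` is the only member of the set that comes with a number. In a functional assay on PC-3 cells (Homo sapiens) for cytotoxicity, read by MTT assay, with a stated time of 48 h (on this read-out lower numbers stand for stronger inhibition and higher numbers for weaker inhibition), compound 1 gives 18200 nM. Compound 2 `O=c1ccc2cc(OCc3cc(-c4cccc([N+](=O)[O-])c4)no3)ccc2o1` has no result in this assay, where compound 2 stands at "not determined" (no result reported). Compound 3 `O=c1ccc2cc(OCc3cc(-c4ccc([N+](=O)[O-])cc4)no3)ccc2o1` is in the same position, with compound 3 at "not determined" (no result reported). Compound 1 therefore stands alone as the single measured point, and nothing can be said about how compound 2 or compound 3 compare with it.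

Compound 4 `COc1ccccc1-c1cc(COc2ccc3oc(=O)ccc3c2)on1` differs from compound 1 in one place: methoxy in place of chloro on an aromatic carbon. The chloro leaves and a methoxy enters on an aromatic carbon of a six-membered aromatic ring of carbon only, ortho to a large group; cut one bond further out, the change reads 2-chlorophenyl to 2-methoxyphenyl.

For the measured compounds named here, no step between measured compounds exists in this set, so there is no measured precedent for this exchange. The step of a 1.1-fold higher number from compound 1 to compound 4 (0.04 log units; within the scatter) is expected to stay within the usual scatter, with no direction favoured. Compound 4 is accordingly estimated to give 20000 nM in this assay, expected to fall between 7000 nM and 60000 nM.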

Compound 4, half-maximal inhibitory concentration: 22400 nM
Estimate against measurement, compound 4: 1.1-fold (0.05 log units) below; the measured number falls inside the stated range.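

In this assay, the exchange of chloro for methoxy on an aromatic carbon of this ring, ortho to a large group, comes out as a 1.2-fold higher number from compound 1 to compound 4 (0.09 log units; within the scatter), so the 2-chlorophenyl and 2-methoxyphenyl compounds cannot be told apart on this read-out. This gives the series its first measured step and shows that, at this one place, a substituent with 2 heavy atoms and 1 hydrogen-bond acceptor can replace one with 1 heavy atom and 0 hydrogen-bond acceptors without a shift beyond the scatter. No data that bear on the reason for this result are available.

The finding rests on a single pair, compound 1 and compound 4, and cannot be extended to other substituents or to other places on the ring. From the compounds shown here alone, whether the read-out would hold with an amine, a carboxylic acid or a longer chain such as ethoxy on the same aromatic carbon remains open.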